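The compounds below may be only part of what the source reports. "The series", "measured", "known", "first", "only" and "open" are said of these compounds alone.

Compound 2 `Cc1ccccc1C(=O)Nc1ccc(C(=O)N2CCCC(NCCC(=O)N3CCOCC3)c3cc(Cl)ccc32)c(C)c1` is the stronger of the two measured compounds in an assay on HEK293 cells for displacement of a labelled ligand from Vasopressin V2 receptor (Homo sapiens), read by HTRF, with a stated time of 2 h (on this read-out higher numbers stand for weaker inhibition and lower numbers for stronger inhibition), where compound 2 gives 3.8 nM. Within the data shown here, its nearest neighbour, compound 1 `Cc1ccccc1C(=O)Nc1ccc(C(=O)N2CCCC(NCCCc3ccncc3)c3cc(Cl)ccc32)c(C)c1`, gives 10 nM in this assay, and the only measured step, a 2.6-fold lower number from compound 1 to compound 2 (0.42 log units; beyond the scatter), is modest but beyond the scatter.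

Compound 3 `CCN(CC)CCCNC1CCCN(C(=O)c2ccc(NC(=O)c3ccccc3C)cc2C)c2ccc(Cl)cc21` has not been measured. It differs from compound 2 in one place: (diethylamino)methyl in place of (morpholin-4-yl)carbonyl on a saturated chain carbon, two bonds along the chain from an amine nitrogen. The step from compound 1 to compound 2 exchanged a group at the same place but it did not involve the (diethylamino)methyl group, so it bears on this change only loosely; it shows that swapping the chain end moves the number by a modest amount.

Without a directly comparable step, compound 3 is expected to land close to compound 2, with a small step of a 1.6-fold higher number from compound 2 to compound 3 (0.20 log units; within the scatter) that may fall within the scatter. The estimate for compound 3 is 6 nM, with a range from 2 nM to 20 nM.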

Compound 3, inhibition constant: 31 nM
Compound 3: the middle estimate sits 5.2-fold (0.71 log units) below what was measured; the whole stated range lies below it.
By their numbers in this assay, from the lowest: compound 2; then compound 1; then compound 3.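

In this assay, among these compounds, the end of this chain now shows a wider spread: exchanging (morpholin-4-yl)carbonyl for (diethylamino)methyl gives an 8.2-fold higher number from compound 2 to compound 3 (0.91 log units; beyond the scatter), a larger move than the one earlier step at this place. Exchanging pyridin-4-yl for diethylamino also weakens inhibition, with a 3.1-fold higher number from compound 1 to compound 3 (0.49 log units; beyond the scatter), so of these three chain ends the diethylamino end gives the weakest inhibition, and both steps to it lie beyond the scatter. Nothing shown here explains why the three chain ends fall in this order.

The compounds shown leave open whether a dimethylamino or piperidin-1-yl end on the same chain would read closer to compound 2 or to compound 3. They also leave open how a shorter chain ending in the morpholine amide would read.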